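The compounds below may be only part of what the source reports. "The series", "measured", "known", "first", "only" and "open" are said of these compounds alone.

Measured compounds in a functional assay on DU-145 cells (Homo sapiens) for cytotoxicity, read by sulforhodamine B assay, with a stated time of 24 h; a lower number here means a stronger inhibitor of growth, a higher number a weaker inhibitor of growth:
- compound 1, `COc1ccc(C(=O)/C=C/c2cc3ccccc3[nH]c2=O)cc1`: 11200 nM
- compound 2, `O=C(/C=C/c1cc2ccccc2[nH]c1=O)c1ccc(O)cc1`: 14300 nM

Among the measured compounds shown here, compound 2 holds the higher of the two numbers, but its only neighbour, compound 1, lies close: the step of a 1.3-fold higher number from compound 1 to compound 2 (0.11 log units; within the scatter) is within the scatter, so the two cannot be ordered on these data.

Compound 3, `O=C(/C=C/c1cc2ccccc2[nH]c1=O)c1ccc(Cl)cc1`, differs from compound 2 by chloro in place of hydroxy on an aromatic carbon. For the measured compounds named here, no measured step changes a hydroxy to a chloro. Going by the values given here, the one step that is known, from compound 1 to compound 2, touches the same ring position in the shared core, swapping methyl for hydrogen on the oxygen there, and it moved the number by a 1.3-fold higher number from compound 1 to compound 2 (0.11 log units; within the scatter), within the scatter. Among the compounds with values here, that is the only evidence bearing on the step to compound 3, and it shows the assay tolerating a change at this position without a shift beyond the scatter.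

On that basis compound 3 is expected to give a number near those of compounds 1 and 2, with the step of a 1.4-fold lower number from compound 2 to compound 3 (0.16 log units; within the scatter) in this assay expected to lie within the scatter. The estimate for compound 3 is 10000 nM, with a range from 4000 nM to 28000 nM.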

Compound 3, concentration for total growth inhibition: 48900 nM
The estimate for compound 3 lay 4.9-fold (0.69 log units) below the measured number, and the stated range ends below it.
By their numbers in this assay, from the lowest: compounds 1 and 2 (each within the scatter of the next); then compound 3.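

The aromatic carbon para to a large group proves not to be indifferent in this assay: chloro in place of hydroxy gives a 3.4-fold higher number from compound 2 to compound 3 (0.53 log units; beyond the scatter), and chloro in place of methoxy gives a 4.4-fold higher number from compound 1 to compound 3 (0.64 log units; beyond the scatter), so both steps to the chloro compound lie beyond the scatter, whereas the change on the oxygen between the two earlier compounds did not. Among these three compounds, then, the two that keep an oxygen on this carbon stay together, within the scatter of each other, and the 4-chlorophenyl compound stands apart as the weaker inhibitor of growth, with no compound shown going against that split. Nothing available explains why the chloro group separates from the two oxygen-bearing groups.

The compounds shown leave open whether the shift belongs to chloro itself or to the loss of oxygen from this carbon, a question that an amine, a fluoro group or a plain hydrogen at the same place would bear on. They also leave open whether a longer chain on the oxygen, such as ethoxy, would stay with compounds 1 and 2.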